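The compounds below may be only part of what the source reports. "The series", "measured", "known", "first", "only" and "open" are said of these compounds alone.

Measured compounds in the series:

- compound 1 `Cc1ccc(CCSc2nc3c(c(=O)n(C)c(=O)n3C)n2C)cc1`: 125000 nM
- compound 2 `COc1ccc(CCSc2nc3c(c(=O)n(C)c(=O)n3C)n2C)cc1`: 168000 nM
- compound 3 `Cn1c(=O)c2c(nc(SCCc3cccc(Br)c3)n2C)n(C)c1=O`: 5700 nM

In an assay on microsomes for inhibition of Amine oxidase [flavin-containing] A (Homo sapiens), read by fluorescence and spectrophotometry, with a stated time of 20 min (a lower number here means a stronger inhibitor, a higher number a weaker inhibitor), compound 2 gives the highest number of the three: compound 1 sits nearest, a 1.3-fold higher number from compound 1 to compound 2 (0.13 log units; within the scatter), and compound 3 furthest, a 29-fold lower number from compound 2 to compound 3 (1.47 log units; beyond the scatter). Compound 4 `COc1cccc(CCSc2nc3c(c(=O)n(C)c(=O)n3C)n2C)c1` is not yet measured. It differs from compound 2 in one place: 3-methoxyphenyl in place of 4-methoxyphenyl on a saturated chain carbon, two bonds along the chain from a sulfur.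

Among the measured compounds shown here, no measured step moves the methoxy alone from one ring position to another. For the measured compounds named here, the steps that bear on the change are a 22-fold lower number from compound 1 to compound 3 (1.34 log units; beyond the scatter) and a 29-fold lower number from compound 2 to compound 3 (1.47 log units; beyond the scatter), both large, both toward a lower number, but each swaps the substituent as well as its position, so how much of the drop belongs to the position is unknown. Some lowering in this assay is therefore expected for compound 4, smaller than these two steps and with wide uncertainty; the estimated step is a 4.2-fold lower number from compound 2 to compound 4 (0.62 log units; beyond the scatter). The estimate for compound 4 is 40000 nM, in the range 8000 nM to 170000 nM.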

Compound 4, half-maximal inhibitory concentration: 48100 nM
Estimate against measurement, compound 4: 1.2-fold (0.08 log units) below; low and high end bracket the measured number.
By their numbers in this assay, from the lowest: compound 3; then compound 4; then compounds 1 and 2 (each within the scatter of the next).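

In this assay, among the compounds shown here, the step of a 3.5-fold lower number from compound 2 to compound 4 (0.54 log units; beyond the scatter) isolates the change of ring position with the methoxy kept, showing that position alone moves the number beyond the scatter, which the earlier steps could not separate from the change of substituent. The substituent still matters with the position held, since an 8.4-fold higher number from compound 3 to compound 4 (0.93 log units; beyond the scatter) shows that 3-methoxyphenyl does not match 3-bromophenyl. The step of a 2.6-fold lower number from compound 1 to compound 4 (0.41 log units; beyond the scatter) shows 3-methoxyphenyl also giving a lower number than 4-methylphenyl, although that step changes both the group and its position.

Nothing measured here accounts for these differences.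
Still open, as far as these compounds go, are how 4-bromophenyl would compare with 3-bromophenyl, and whether an amine or a carboxylic acid in place of the methoxy would keep the lower number.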